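The source may report more compounds than this note shows. Statements on the series, on what has been measured and on what is new or still open speak of the compounds shown alone.

Measured compounds in a physicochemical assay for lipophilicity, measured as octanol-water partition; a lower number here means a more polar compound, a higher number a more lipophilic compound:

Compound 1, `O=C(NNc1ccnc2cc(Cl)ccc12)c1ccccc1/N=C/c1ccc(Cl)cc1`: 5.62
Compound 2, `Cc1ccc(/C=N/c2ccccc2C(=O)NNc2ccnc3cc(Cl)ccc23)cc1`: 5.31
Compound 3, `O=C(NNc1ccnc2cc(Cl)ccc12)c1ccccc1/N=C/c1ccc(O)cc1`: 4.65

Compound 2 stands second highest of the three numbers in this assay. Its nearest neighbour is compound 1, reached by a number 0.31 log units lower from compound 1 to compound 2 (beyond the scatter), and its furthest is compound 3, reached by a number 0.66 log units lower from compound 2 to compound 3 (beyond the scatter); both steps lie beyond the scatter. The third step, a number 0.97 log units lower from compound 1 to compound 3 (beyond the scatter), also lies beyond the scatter, so the three values are ordered.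

The step now followed goes from compound 2 to compound 4, `O=C(NNc1ccnc2cc(Cl)ccc12)c1ccccc1/N=C/c1cc2ccccc2nc1Cl`, with the change (2-chloroquinolin-3-yl in place of 4-methylphenyl on a carbon with a double bond to nitrogen). The measured steps all swap one substituent on the same aromatic ring; none of them exchanges the whole aryl group on the carbon with a double bond to nitrogen, so none bears directly on this change. What they do show is that a chloro group gives a higher number than a methyl group, by a number 0.31 log units lower from compound 1 to compound 2 (beyond the scatter). The entering 2-chloroquinolin-3-yl brings a chlorine and a second ring but also one hydrogen-bond acceptor, and these are expected to partly offset one another, so a modest rise is expected in this assay, a number 0.29 log units higher from compound 2 to compound 4 (within the scatter). Compound 4 is therefore estimated at 5.6, within a range from 5.1 to 6.1.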

Compound 4, partition coefficient: 6
Beside the measured number, compound 4's estimate is 0.40 log units below it, and the stated range covers the measured number.
By their numbers in this assay, from the lowest: compound 3; then compound 2; then compound 1; then compound 4.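

In this assay, exchanging the whole aryl group on the carbon with a double bond to nitrogen gave steps beyond the scatter from all three earlier compounds, the first time this position had been changed as a whole (a number 0.69 log units higher from compound 2 to compound 4 (beyond the scatter); a number 0.38 log units higher from compound 1 to compound 4 (beyond the scatter); a number 1.35 log units higher from compound 3 to compound 4 (beyond the scatter)). Compound 4 therefore has the highest number of the four, and the hydrogen-bond acceptor counted in 2-chloroquinolin-3-yl, absent from 4-methylphenyl, did not keep the number of compound 4 down at the level of compound 2 or compound 1. No measurement shown accounts for the size of these steps or divides them among the chlorine, the second ring and the ring nitrogen.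

From the compounds shown here alone, the share of each of those three parts stays open, and a quinolin-3-yl group without its chlorine would be the direct comparison with compound 4. Also open is how far the number in this assay would move with an amine or a carboxylic acid on the entering group, since the only groups shown at this position are the four aryl groups of compound 1, compound 2, compound 3 and compound 4.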